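Series notes: substituent exchange at the saturated ring carbon

The compounds below may be only part of what the source reports. "The series", "measured", "known", "first", "only" and "open" are said of these compounds alone.

Measured so far, all in a functional assay on HEK293 cells for agonist activity at G-protein coupled receptor 39 (Homo sapiens), read by scintillation proximity assay and inositol phosphate accumulation, with a stated time of 75 min, in the presence of a further agent that is not named here; a lower number here means that less compound is needed, a higher number that more compound is needed for the effect:
Compound 1, `Cc1nn(-c2ncnc3nc[nH]c23)c2c1C(c1ccc(OC(C)C)cc1)CC(=O)N2`: 18 nM
Compound 2, `Cc1nn(-c2ncnc3nc[nH]c23)c2c1C(OCCc1ccccc1)CC(=O)N2`: 3 nM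
Compound 3, `Cc1nn(-c2ncnc3nc[nH]c23)c2c1C(NC(=O)Cc1cccs1)CC(=O)N2`: 3 nM

Compound 3 stands level with compound 2 at the digits shown, and the two together give the lowest numbers of the three. Against compound 1 the step is a 6.0-fold lower number from compound 1 to compound 3 (0.78 log units; beyond the scatter). The step of no change at the digits printed from compound 2 to compound 3 (within the scatter) shows that swapping phenethyloxy for (((thiophen-2-yl)methyl)carbonyl)amino leaves the number where it was.

Compound 4, `Cc1nn(-c2ncnc3nc[nH]c23)c2c1C(OCc1ccccc1C#N)CC(=O)N2`, is not yet measured. It differs from compound 3 by (2-cyanobenzyl)oxy in place of (((thiophen-2-yl)methyl)carbonyl)amino on a saturated ring carbon. Among the measured compounds shown here, the steps that bear on this are a 6.0-fold lower number from compound 1 to compound 2 (0.78 log units; beyond the scatter) and a 6.0-fold lower number from compound 1 to compound 3 (0.78 log units; beyond the scatter), both modest, and no change at the digits printed from compound 2 to compound 3 (within the scatter), within the scatter. Compound 4 carries a group of the same kind as phenethyloxy in compound 2, which read level with compound 3. For compound 4 the expected step is therefore a 1.3-fold higher number from compound 3 to compound 4 (0.12 log units; within the scatter), nothing beyond the scatter. In this assay compound 4 is estimated at 4 nM, with a range of 1.5 nM to 12 nM.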

Compound 4, half-maximal effective concentration: 8 nM
Compound 4: middle estimate off by 2.0-fold (0.30 log units), on the low side; the measured number falls inside the stated range.
By their numbers in this assay, from the lowest: compounds 2 and 3 (each within the scatter of the next); then compound 4; then compound 1.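

In this assay, an oxygen-linked group at this saturated ring carbon does not guarantee a match with the compound 3 level: the result is a 2.7-fold higher number from compound 3 to compound 4 (0.43 log units; beyond the scatter), and within the ether pair it is a 2.7-fold higher number from compound 2 to compound 4 (0.43 log units; beyond the scatter), so the two ethers, unlike compound 2 and compound 3, are separated beyond the scatter. The (2-cyanobenzyl)oxy group still improves on 4-isopropoxyphenyl, with a 2.3-fold lower number from compound 1 to compound 4 (0.35 log units; beyond the scatter), which places compound 4 between the two earlier levels. Nothing available here explains these differences.

Compound 4 differs from compound 2 in both the nitrile and the length of the chain on the oxygen, and plain benzyloxy would separate those two changes. On these data alone, how an amine, a carboxylic acid or a longer chain on the oxygen would read at this carbon stays open.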